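The source may report more compounds than this note shows. Statements on the series, on what has been measured and on what is new or still open speak of the compounds shown alone.

Measured compounds in an in vitro assay on HEK-tsA201 cells for antagonist activity at Neuronal acetylcholine receptor; alpha3/beta4 (Homo sapiens), read by fluorescence and calcium flux; on this read-out lower numbers stand for stronger inhibition and higher numbers for weaker inhibition:
compound 1 `CCCOc1ccc(C(=O)Nc2cccc(C)n2)cc1` gives 11100 nM;
compound 2 `CCCOc1ccc(C(=O)Nc2cccc(CC)n2)cc1` gives 29200 nM;
compound 3 `CCCCNc1cccc(NC(=O)c2ccc(OCCC)cc2)n1` gives 77800 nM.

Compound 3 gives the highest number of the three, beyond the scatter from both others. Both steps into it go the same way: a 7.0-fold higher number from compound 1 to compound 3 (0.85 log units; beyond the scatter) and a 2.7-fold higher number from compound 2 to compound 3 (0.43 log units; beyond the scatter), so the butylamino group in place of a small alkyl group on the aromatic carbon has so far raised the number.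

Compound 4 `CCCOc1ccc(C(=O)Nc2cccc(Nc3ccccc3)n2)cc1` keeps the amino nitrogen and alters what it carries: phenyl in place of butyl on a nitrogen on an aromatic ring. For the measured compounds named here, no measured pair in this set swaps one substituent for another on that nitrogen, so the only bearing is indirect: the series has moved in modest steps, and the two steps ending at compound 3 were both modest. A modest shift is therefore the expectation here, with direction uncertain; a step within the scatter is as plausible as one beyond it. Compound 4 is expected to give about 60000 nM in this assay, within 20000 nM to 180000 nM. The expected step is a 1.3-fold lower number from compound 3 to compound 4 (0.11 log units; within the scatter).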

Compound 4, half-maximal inhibitory concentration: > 100000 nM
Compound 4 was reported as a limit; the forecaster's own chance of this, stated with the estimate: 35%; at least 1.6-fold (0.22 log units) between middle value and limit.
By their numbers in this assay, from the lowest: compound 1; then compound 2; then compound 3. At a limit, above all of these: compound 4.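

In this assay compound 4 stands only as a limit, and the reading ends there: the limit of > 100000 nM in this assay, at which 1 of the 4 values shown sits. Phenyl in place of butyl on the nitrogen gives an at least 1.2-fold higher number from compound 3 to compound 4 (0.10 log units; that floor lies within the scatter), so the floor of this step does not separate the two compounds beyond the scatter, but an aromatic ring on that nitrogen does not return the number to the range of the small alkyl compounds. Anilino stays higher than both small alkyl groups, with an at least 3.4-fold higher number from compound 2 to compound 4 (0.53 log units; beyond the scatter) and an at least 9.0-fold higher number from compound 1 to compound 4 (0.95 log units; beyond the scatter), so butylamino and anilino both read higher than methyl and ethyl on this aromatic carbon.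

On these data alone, how far compound 4 lies past its limit remains open, and with it the true size of the step from compound 3. Also open, as far as these compounds go, is whether a free amine or a methylamino group on this aromatic carbon would bring the number down to that of compound 1.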